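The source may hold more compounds than are shown below. What is called first, only, known or untested is meant among the compounds shown, and "the series" means these compounds.

Measured compounds:
- compound 1 `COc1cc(OC)c2sc(-c3ccc(N/C=C\C(=O)c4cc(OC)c(OC)c(OC)c4)cc3)nc2c1`: 26800 nM
- compound 2 `COc1cc(OC)c2sc(-c3ccc(N/C=C\C(=O)c4ccc(OC)c(F)c4)c(C)c3)nc2c1`: 16300 nM
- compound 3 `COc1cc(OC)c2sc(-c3ccc(N/C=C\C(=O)c4ccc(OC)c([N+](=O)[O-])c4)c(C)c3)nc2c1`: 13900 nM

In a functional assay on MIA PaCa-2 cells (Homo sapiens) for antiproliferative activity, read by sulforhodamine B assay, with a stated time of 48 h (on this read-out lower numbers stand for stronger inhibition and higher numbers for weaker inhibition), compound 3 holds the lowest of the three numbers, yet no order can be read from them: the step of a 1.2-fold lower number from compound 2 to compound 3 (0.07 log units; within the scatter) is within the scatter, and the gap between compound 1 and compound 3 is also within the scatter, so the three compounds sit together on this read-out.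

Compound 4 `COc1cc(OC)c2sc(-c3ccc(N/C=C\C(=O)c4ccc(OC)c(O)c4)c(C)c3)nc2c1` differs from compound 3 by hydroxy in place of nitro on an aromatic carbon. For the measured compounds named here, the only one-place step measured, a 1.2-fold lower number from compound 2 to compound 3 (0.07 log units; within the scatter), concerned a different pair of groups and did not leave the scatter; nothing measured here shows a hydroxy entering. The expectation for compound 4 is therefore a step of a 1.1-fold lower number from compound 3 to compound 4 (0.03 log units; within the scatter), with no movement beyond the scatter. Compound 4 is estimated at 13000 nM, in a range from 4500 nM to 40000 nM.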

Compound 4, half-maximal inhibitory concentration: 22100 nM
For compound 4 the middle estimate is 1.7-fold (0.23 log units) below the measured one, within the range that was stated.
By their numbers in this assay, from the lowest: compounds 3, 2, 4 and 1 (each within the scatter of the next).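

In this assay, the aromatic carbon ortho to a methoxy group takes hydroxy with no separation from the other groups: a 1.6-fold higher number from compound 3 to compound 4 (0.20 log units; within the scatter) and a 1.4-fold higher number from compound 2 to compound 4 (0.13 log units; within the scatter) both stay within the scatter. Nitro has no hydrogen-bond donor and hydroxy has one, yet this change, 4-methoxy-3-nitrophenyl to 3-hydroxy-4-methoxyphenyl, gives no readable difference on this read-out. No supporting measurement bears on this result. From the compounds shown here alone, whether any group at this position can leave the scatter remains open. An amine or a carboxylic acid here would test that.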